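Piperidin-1-yl for cyclohexyl on a methylsulfonyl acylguanidine core

This account rests on a few compounds, and the source may have more. Where it says the series, first, only, none or still open, it means among the compounds named here.

Compound 1 `Cc1ccc(-c2ccc(C(=O)N=C(N)N)cc2S(C)(=O)=O)cc1`: in a functional assay for inhibition of sodium/hydrogen exchanger (Oryctolagus cuniculus) (on this read-out lower numbers stand for stronger inhibition and higher numbers for weaker inhibition), compound 1 gives 100 nM
Compound 2 `CS(=O)(=O)c1cc(C(=O)N=C(N)N)ccc1Oc1cccnc1`: in this assay compound 2 gives 76 nM
Compound 3 `CS(=O)(=O)c1cc(C(=O)N=C(N)N)ccc1C1CCCCC1`: in this assay compound 3 gives 340 nM

Compound 3 carries the highest number of the three, which on this read-out means the weakest inhibition. The steps leading to it were a 3.4-fold higher number from compound 1 to compound 3 (0.53 log units; beyond the scatter) and a 4.5-fold higher number from compound 2 to compound 3 (0.65 log units; beyond the scatter), both beyond the scatter, whereas a 1.3-fold lower number from compound 1 to compound 2 (0.12 log units; within the scatter) stayed within it. Compound 4 `CS(=O)(=O)c1cc(C(=O)N=C(N)N)ccc1N1CCCCC1` differs from compound 3 in one place: piperidin-1-yl in place of cyclohexyl on an aromatic carbon. For the measured compounds named here, no measured step exchanges one saturated six-membered ring for another, so the two steps that reach compound 3 bear on this change only loosely; they show that the saturated ring gave a higher number than either aromatic group, but say nothing about a ring nitrogen. Compound 4 is therefore expected to stay close to compound 3, with at most a modest move toward lower numbers, estimated at 220 nM within a range of 60 nM to 800 nM. The expected step is a 1.5-fold lower number from compound 3 to compound 4 (0.19 log units; within the scatter).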

Compound 4, half-maximal inhibitory concentration: 130 nM
Compound 4: the middle estimate sits 1.7-fold (0.23 log units) above what was measured; low and high end bracket the measured number.
By their numbers in this assay, from the lowest: compounds 2, 1 and 4 (each within the scatter of the next); then compound 3.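

In this assay, replacing the cyclohexyl ring with the piperidin-1-yl ring gives a 2.6-fold lower number from compound 3 to compound 4 (0.42 log units; beyond the scatter) on this aromatic carbon, the first sign that a ring nitrogen at this position changes the result even though the ring keeps its six members. The higher number of compound 3 therefore does not extend to every saturated six-membered ring here. Piperidin-1-yl instead stands level with the two aromatic groups, with a 1.7-fold higher number from compound 2 to compound 4 (0.23 log units; within the scatter) and a 1.3-fold higher number from compound 1 to compound 4 (0.11 log units; within the scatter) both printed as within the scatter.

As far as these compounds go, whether a morpholin-4-yl ring, a smaller pyrrolidin-1-yl ring or an open-chain dimethylamino group would behave like piperidin-1-yl remains open. Nothing available explains why the nitrogen-containing ring gives the lower number.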